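This account rests on a few compounds, and the source may have more. Where it says the series, first, only, none or still open, it means among the compounds named here.

Compound 1 `O=C1C=C[C@@H](OCc2ccccc2)[C@@H]([C@@H](COC(=O)/C=C/c2ccc(F)cc2)OCc2ccccc2)O1` and compound 2 `O=C1C=C[C@@H](OCc2ccccc2)[C@@H]([C@@H](COC(=O)/C=C/c2ccc([N+](=O)[O-])cc2)OCc2ccccc2)O1` share one core. In a functional assay on Raji cells (Homo sapiens) for antiproliferative activity, read by MTT assay, with a stated time of 6 days (on this read-out higher numbers stand for weaker inhibition and lower numbers for stronger inhibition), compound 1 gives 2470 nM and compound 2 gives 140 nM. The change between them, (nitro in place of fluoro on an aromatic carbon), produces an 18-fold lower number from compound 1 to compound 2 (1.25 log units; beyond the scatter). Compound 3 `CC(=O)O[C@@H]1C=CC(=O)O[C@@H]1[C@@H](COC(=O)/C=C/c1ccc(F)cc1)OC(C)=O` rests on another core; the difference between the two cores is not broken down here. In this assay compound 3 gives 2310 nM, a number within the scatter of compound 1. Compound 4 `CC(=O)O[C@@H]1C=CC(=O)O[C@@H]1[C@@H](COC(=O)/C=C/c1ccc([N+](=O)[O-])cc1)OC(C)=O` is derived from compound 3 by the same change, (nitro in place of fluoro on an aromatic carbon), at the same place. For compound 4 a step of similar size is expected, a 15-fold lower number from compound 3 to compound 4 (1.19 log units; beyond the scatter). Among the measured compounds shown here, this rests on the single measured instance in compound 1 and compound 2, where the change gave an 18-fold lower number from compound 1 to compound 2 (1.25 log units; beyond the scatter), well beyond the scatter; with one precedent only, the size remains uncertain. In this assay compound 4 is thus estimated at 150 nM, between 60 nM and 450 nM.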

Compound 4, half-maximal inhibitory concentration: 2750 nM
Compound 4: the middle estimate sits 18-fold (1.26 log units) below what was measured; the whole stated range lies below it.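

In this assay, nitro in place of fluoro does not carry over from one core to the other: the same change on two cores in this assay, an 18-fold lower number (1.25 log units; beyond the scatter) from compound 1 to compound 2 and a 1.2-fold higher number (0.08 log units; within the scatter) from compound 3 to compound 4, 21-fold (1.32 log units) apart, beyond the scatter of two such steps. Among the compounds shown here, on the second core the change gives a 1.2-fold higher number from compound 3 to compound 4 (0.08 log units; within the scatter), so the step measured on the first core is no guide to its size on the second. For the compounds shown here, with one pair on each core, this shows only that the two cores respond differently to this single change; it does not show which part of the cores accounts for the gap, or how any other change would carry over.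

Still open, from the compounds shown here alone, is whether an amine or a carboxylic acid in the same place on the aromatic ring would also separate the two cores. Also open, going by these compounds, is whether the nitro step on the first core recurs with other groups.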